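The compounds below may be only part of what the source reports. "The series", "measured", "known", "first", "only" and "open" are said of these compounds alone.

Values in a functional assay on DU-145 cells (Homo sapiens) for inhibition, read by trypan blue exclusion, with a stated time of 72 h; on this read-out higher numbers stand for weaker inhibition and lower numbers for stronger inhibition

- Compound 1 `O=c1c(S(=O)(=O)c2ccc(F)cc2F)cc2cnc(Nc3ccc4[nH]ccc4c3)nc2n1C1CCCC1` gives 5000 nM
- Compound 2 `O=c1[nH]c2nc(Nc3ccc4[nH]ccc4c3)ncc2cc1S(=O)(=O)c1ccc(F)cc1F` gives 15000 nM
- Compound 3 `O=c1c(S(=O)(=O)c2ccc(F)cc2F)cc2cnc(Nc3ccc4[nH]ccc4c3)nc2n1CC1CC1` gives 1000 nM

Compound 3 has the lowest number of the three, and its steps to compound 1 and compound 2 both lie beyond the scatter. The next compound, compound 4 `O=c1c(S(=O)(=O)c2ccc(F)cc2F)cc2cnc(Nc3ccc4[nH]ccc4c3)nc2n1C1CCCCC1`, carries cyclohexyl in place of cyclopropylmethyl on an aromatic nitrogen. Among the measured compounds shown here, no measured compound carries cyclohexyl, so the estimate rests on neighbouring steps at the same place.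

The closest guide is the modest 5.0-fold lower number from compound 1 to compound 3 (0.70 log units; beyond the scatter) for cyclopropylmethyl in place of cyclopentyl. The large 15-fold lower number from compound 2 to compound 3 (1.18 log units; beyond the scatter) for cyclopropylmethyl in place of hydrogen and the modest 3.0-fold higher number from compound 1 to compound 2 (0.48 log units; beyond the scatter) for hydrogen in place of cyclopentyl show that the number also depends on the group at this place. Cyclohexyl resembles the cyclopentyl of compound 1 more than it resembles cyclopropylmethyl, since each is a non-aromatic ring of carbon only. A modest step to a higher number is therefore expected in this assay, reversing most or all of the gain seen with cyclopropylmethyl, and the expected size is a 4.5-fold higher number from compound 3 to compound 4 (0.65 log units; beyond the scatter) for this change. For compound 4 the estimated value is 4500 nM, with an expected range from 1500 nM to 13000 nM.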

Compound 4, half-maximal inhibitory concentration: 10000 nM
For compound 4 the middle estimate is 2.2-fold (0.35 log units) below the measured one; the measured number falls inside the stated range.
By their numbers in this assay, from the lowest: compound 3; then compounds 1, 4 and 2 (each within the scatter of the next, the first and the last beyond it).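

In this assay the lower number at this aromatic nitrogen proves tied to cyclopropylmethyl and is not shared by every carbon group placed there, as the step of a 10-fold higher number from compound 3 to compound 4 (1.00 log units; beyond the scatter) gives back what that group had gained. Cyclohexyl cannot be told apart from either earlier neighbour, with a 2.0-fold higher number from compound 1 to compound 4 (0.30 log units; within the scatter) for the exchange of cyclopentyl and a 1.5-fold lower number from compound 2 to compound 4 (0.18 log units; within the scatter) for the exchange of hydrogen, so the larger ring shows no clear advantage over the bare nitrogen, although cyclopentyl had one in the earlier step of a 15-fold lower number from compound 2 to compound 3 (1.18 log units; beyond the scatter) only relative to cyclopropylmethyl's larger reach and in a 3.0-fold higher number from compound 1 to compound 2 (0.48 log units; beyond the scatter) on its own. Nothing available here explains why the number follows the group at this place.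

The compounds shown leave open whether the ring of cyclopropylmethyl matters or whether its short link to the nitrogen does, which cyclopropyl placed directly on the nitrogen, or an open chain such as isobutyl, would help to separate. They also leave open whether a chain ending in an amine or a hydroxyl would be tolerated at this nitrogen.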